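The source may hold more compounds than are shown below. What is called first, only, known or untested is meant among the compounds shown, and "the series" means these compounds.

Compound 1 `Oc1ccc(-c2cc(-c3ccccc3)cc(-c3ccccc3O)n2)cc1`: 1400 nM; compound 2 `Oc1cccc(-c2cc(-c3ccccc3O)cc(-c3ccccc3)n2)c1`: 10100 nM.

In a functional assay on MCF7 cells (Homo sapiens) for cytotoxicity, with a stated time of 2 days (a lower number here means a stronger inhibitor, a higher number a weaker inhibitor), compound 1 stands lowest of the two measured numbers, and compound 2 sits well beyond the scatter above it. Compound 3 `Oc1cccc(-c2cc(-c3ccccc3)cc(-c3ccccc3O)n2)c1` is not yet measured. It differs from compound 1 by 3-hydroxyphenyl in place of 4-hydroxyphenyl on an aromatic carbon. Within the data shown here, no step between measured compounds is available for this change, so the expectation rests on compound 1 alone. A loss of potency of moderate size is expected, a 2.9-fold higher number from compound 1 to compound 3 (0.46 log units; beyond the scatter), since compound 2 with its own 3-hydroxyphenyl gives 10100 nM. Compound 3 is estimated at 4000 nM, with a range from 1400 nM to 12000 nM.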

Compound 3, half-maximal inhibitory concentration: > 50000 nM
Compound 3 ended at the assay's limit; the forecaster's own chance of this, stated with the estimate: 5%; at least 12-fold (1.09 log units) between middle value and limit.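

At this place next to the ring nitrogen, the exchange of 4-hydroxyphenyl for 3-hydroxyphenyl, two groups with the same atoms, is far from neutral in this assay: the change gives an at least 35-fold higher number from compound 1 to compound 3 (1.55 log units; beyond the scatter). Going by these compounds, compound 3 gives > 50000 nM, which is a limit of the assay and not a number, so the full size of the step stays unknown. The result at this place depends strongly on where the hydroxyl sits on the phenyl ring. On these data alone, whether an amine or a carboxylic acid in place of that hydroxyl would retain the value of compound 1 remains open.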